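This account rests on a few compounds, and the source may have more. Where it says the series, first, only, none or still open, it means among the compounds named here.

Measured so far:
compound 1 `O=C(O)Cc1sc(C(c2ccccc2)c2ccc(Cl)cc2)nc1-c1ccc(Cl)cc1`, 80%
compound 2 `O=C(O)Cc1sc(C(c2ccccc2)c2ccc(Cl)cc2)nc1-c1ccc(F)cc1`, 80%
compound 3 `Nc1cc(-c2nc(C(c3ccc(F)cc3)c3ccc(F)cc3)sc2CC(=O)O)cc(F)n1`, 30%

All three were run in an in vitro functional assay on HEK285-7 cells for antagonist activity at prostaglandin D2 receptor 2 (Homo sapiens), read by BRET and beta-arrestin recruitment; on this read-out lower numbers stand for smaller maximal responses and higher numbers for larger maximal responses. Compound 1 stands level with compound 2 at the digits given, the two together the highest of the three numbers; compound 3 lies far below both, well beyond the scatter. Among the measured compounds shown here, the only single-point step, no change at the digits printed from compound 1 to compound 2 (within the scatter), concerns fluoro for chloro on an aromatic carbon.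

Compound 4 `O=C(O)Cc1sc(C(c2ccccc2)c2ccccn2)nc1-c1ccc(Cl)cc1` is not yet measured. It differs from compound 1 by pyridin-2-yl in place of 4-chlorophenyl on a saturated chain carbon bound to two aromatic carbons. For the measured compounds named here, no measured step touches that saturated chain carbon or introduces a pyridin-2-yl, so the step from compound 1 to compound 2 bears only loosely on it; the low value of compound 3 shows the series can lose efficacy, though its change is not a single one. A moderate drop is expected, a number 15 percentage points lower from compound 1 to compound 4 (beyond the scatter), giving compound 4 an estimated 65% with range 35% to 90%.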

Compound 4, largest response reached (reported as efficacy), in percent of the reference or control that the assay uses: 55%
The estimate for compound 4 lay 10 percentage points above the measured number; the range from low to high includes it.
By their numbers in this assay, from the lowest: compound 3; then compound 4; then compounds 1 and 2 (each within the scatter of the next).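

In this assay, pyridin-2-yl in place of 4-chlorophenyl on a saturated chain carbon bound to two aromatic carbons gives a number 25 percentage points lower from compound 1 to compound 4 (beyond the scatter). The maximal response therefore responds to a single change at this carbon, whereas fluoro in place of chloro on an aromatic carbon gave no change at the digits printed from compound 1 to compound 2 (within the scatter). Nothing at hand accounts for this step.

Still open, on these data alone, is whether the step follows the ring nitrogen or the loss of the chloro group. Pyridin-3-yl or an unsubstituted phenyl at this carbon would bear on that question.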